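A few compounds are considered here, and "the series" means these few. Any claim that something is new, unique, unknown or untested is made for them only; others in the source may bear on it.

Among the compounds with values here, compound 1 `CCC(=O)c1ccc(NCc2cncn2Cc2ccc(-c3ccccc3)cc2)cc1-c1ccccc1` is one of two compounds measured in a toxicity assay on NIH3T3 cells (Mus musculus) for cytotoxicity, read by resazurin assay; a higher number here means that more compound is needed for the effect, a lower number that less compound is needed. In this assay compound 1 reaches only a limit, > 10000 nM. Compound 2 `c1ccc(-c2ccc(Cn3cncc3CNc3ccc(-c4cncs4)c(-c4ccccc4)c3)cc2)cc1` differs from compound 1 by a single exchange on the shared core. In this assay compound 2 likewise reaches only a limit, > 1000 nM. The step that the two limits leave unreadable from compound 1 to compound 2 cannot be sized, because the limit of > 1000 nM in this assay, at which 1 of the 2 values shown sits, and the limit of > 10000 nM in this assay, at which 1 of the 2 values shown sits, are both limits and neither gives a number. Within the data shown here, compound 2 therefore stands at a limit, and the one further value shown is a limit as well, so nothing among the measured pairs reads as a change beyond the scatter.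

Compound 3 `c1ccc(-c2ccc(Cn3cncc3CNc3ccc(-c4cc5ccccc5o4)c(-c4ccccc4)c3)cc2)cc1` is not yet measured. It differs from compound 2 in one place: 1-benzofuran-2-yl in place of 1,3-thiazol-5-yl on an aromatic carbon. Among the measured compounds shown here, the only measured step that touches the same position is the one from compound 1 to compound 2, and its size is not readable; no other step bears on this change. For compound 3 the step that the limit leaves unreadable from compound 2 to compound 3 is therefore expected to stay within the scatter. Compound 3 is estimated at 5000 nM in this assay, within a range from 1500 nM to 30000 nM.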

Compound 3, half-maximal effective concentration: > 10000 nM
Compound 3: a limit, no number (the forecaster's own chance of this, stated with the estimate: 70%); middle value at least 2.0-fold (0.30 log units) away from the limit.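

In this assay compound 3 reaches > 10000 nM, which is a limit and not a number. The steps to it from compound 1 and from compound 2 cannot be read. The compounds shown leave open at what concentration any of the three reaches its half-maximal effect in this assay, and whether these exchanges on the aromatic carbon change that concentration at all.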